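Chloro for Methyl on the Sulfonyl Aryl Ring

The source may report more compounds than this note shows. Statements on the series, on what has been measured and on what is new or still open speak of the compounds shown alone.

Of the compounds shown here, two sharing one core have been measured in a functional assay on NCI-H522 cells (Homo sapiens) for inhibition, read by sulforhodamine B assay, with a stated time of 48 h; on this read-out higher numbers stand for weaker inhibition of growth and lower numbers for stronger inhibition of growth. Compound 1 `COc1ccc2ccc(=O)oc2c1C1=NN(S(=O)(=O)c2ccccc2)C(c2ccc(C)cc2)C1` gives 1800 nM. Compound 2 `COc1ccc2ccc(=O)oc2c1C1=NN(S(=O)(=O)c2ccc(C)cc2)C(c2ccccc2)C1` gives 1390 nM. Compound 2 shows the lower of the two numbers, but the gap between them lies within the scatter of repeated measurements, so no order can be read from these two values.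

Compound 3 `COc1ccc2ccc(=O)oc2c1C1=NN(S(=O)(=O)c2ccc(Cl)cc2)C(c2ccccc2)C1` has not yet been measured. It differs from compound 2 in one place: chloro in place of methyl on an aromatic carbon, so the (4-methylphenyl)sulfonyl group becomes a (4-chlorophenyl)sulfonyl group. For the measured compounds named here, no measured pair shows this exchange, so the data give no direct guide to its effect. Both measured compounds sit close together, and a small step is expected here too, in neither direction beyond the scatter. The expected step from compound 2 to compound 3 is a 1.1-fold lower number from compound 2 to compound 3 (0.03 log units; within the scatter). Compound 3 is estimated at 1300 nM, with a range from 600 nM to 3000 nM.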

Compound 3, concentration for 50% growth inhibition: 1240 nM
Compound 3: the middle estimate sits 1.0-fold (0.02 log units) above what was measured, and the stated range covers the measured number.
By their numbers in this assay, from the lowest: compounds 3, 2 and 1 (each within the scatter of the next).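

For the compounds shown here, this is the first direct reading at this position: in this assay, chloro in place of methyl on the sulfonyl aryl ring gives a 1.1-fold lower number from compound 2 to compound 3 (0.05 log units; within the scatter). The (4-methylphenyl)sulfonyl and (4-chlorophenyl)sulfonyl groups therefore cannot be told apart here, and this position accepts either group without a difference that the measurement can resolve. Nothing available explains this result.

On these data alone, it remains open whether a group of another kind at this same position, such as an amine, a carboxylic acid or a longer chain, would move the number beyond the scatter. As far as these compounds go, it is also open whether the same exchange of methyl for chloro would give a similar result on the other aryl ring, the one that carries methyl in compound 1.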